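Trading a Ring for a Short Chain on the Shared Core

The compounds below may be only part of what the source reports. "The series", "measured", "known", "first", "only" and "open" are said of these compounds alone.

Of the compounds shown here, three built on one shared core have been tested in a functional assay on SMMC-7721 cells (Homo sapiens) for cytotoxicity, read by MTT assay, with a stated time of 72 h; a higher number here means a weaker inhibitor, a lower number a stronger inhibitor. Compound 1 `[O-][n+]1nc(NCOC2CCCCC2)[n+]([O-])c2ccccc21` carries a cyclohexyl group on the oxygen of its side chain, and in this assay compound 1 gives 28200 nM, the highest number of the three and so the weakest inhibitor among them. Compound 2 `[O-][n+]1nc(NCOCc2ccc(C(F)(F)F)cc2)[n+]([O-])c2ccccc21`, whose side chain ends in a benzyl group bearing a trifluoromethyl, gives 9450 nM in this assay, and compound 3 `CC(OCNc1n[n+]([O-])c2ccccc2[n+]1[O-])c1ccccc1`, carrying a phenyl-bearing branched group there, gives 12900 nM. Both sit beyond the scatter below compound 1.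

Compound 4 `CCCOCNc1n[n+]([O-])c2ccccc2[n+]1[O-]` has not yet been measured. It differs from compound 1 in one place: propyl in place of cyclohexyl on an oxygen on a saturated carbon. Among the measured compounds shown here, no measured pair shows a step of this kind, so its size is uncertain. The two lower numbers belong to compounds 2 and 3, which both carry a phenyl ring, while compound 4, like compound 1, does not; compound 4 is therefore expected to stay close to compound 1. The step of a 1.1-fold higher number from compound 1 to compound 4 (0.03 log units; within the scatter) is expected to lie within the scatter. Compound 4 is estimated at 30000 nM, between 10000 nM and 90000 nM.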

Compound 4, half-maximal inhibitory concentration: 19500 nM
Estimate against measurement, compound 4: 1.5-fold (0.19 log units) above, within the range that was stated.
By their numbers in this assay, from the lowest: compounds 2, 3, 4 and 1 (each within the scatter of the next, the first and the last beyond it).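

In this assay, putting propyl in place of cyclohexyl on this oxygen gives a 1.4-fold lower number from compound 1 to compound 4 (0.16 log units; within the scatter). Among the compounds shown here, this is the first step that changes one place alone, and it shows that here the six-membered carbon ring can give way to a shorter open chain with no change beyond the scatter. No measurement at hand accounts for this result.

The compounds shown leave open whether a longer chain such as hexyl, or a chain ending in an amine or a carboxylic acid, would also stay within the scatter of compound 1 at this place. A single step also cannot tell whether a smaller group such as methyl on this oxygen would read the same way.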